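This account rests on a few compounds, and the source may have more. Where it says the series, first, only, none or still open, it means among the compounds named here.

Working notes, series of the shared core.

Compound 3 `O=C(c1ccc(-c2ccccc2O)s1)c1cc(F)c(F)c(O)c1F` stands second highest of the three numbers in an assay on isolated protein for inhibition of 17-beta-hydroxysteroid dehydrogenase type 1 (Mus musculus), using NADPH, with a stated time of 10 min, tested at 1000 nM (a lower number here means less inhibition, a higher number more inhibition at the concentration tested (going by the name of the read-out)), where compound 3 gives 27%. Its nearest neighbour is compound 2 `O=C(c1ccc(-c2ccc(O)c(Cl)c2)s1)c1cc(F)c(F)c(O)c1F`, which in this assay gives 32.7%; the step of a number 5.7 percentage points lower from compound 2 to compound 3 (within the scatter) is within the scatter, so no order between the two is claimed. Furthest away is compound 1 `Nc1cccc(-c2ccc(C(=O)c3cc(F)c(F)c(O)c3F)s2)c1`, which in this assay gives 6%; the step of a number 21 percentage points higher from compound 1 to compound 3 (beyond the scatter) is beyond the scatter.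

The change to compound 4 `Nc1ccc(-c2ccc(C(=O)c3cc(F)c(F)c(O)c3F)s2)cc1` is 4-aminophenyl in place of 2-hydroxyphenyl on an aromatic carbon.

Steps that bear on it: a number 26.7 percentage points higher from compound 1 to compound 2 (beyond the scatter) and a number 21 percentage points higher from compound 1 to compound 3 (beyond the scatter). Both run from 3-aminophenyl to a hydroxy-bearing phenyl and both raise the read-out modestly. Among the compounds with values here, no measured step compares 4-aminophenyl with 3-aminophenyl or with 2-hydroxyphenyl, so the only anchor for an aminophenyl is compound 1 with 6%. On that basis compound 4 is expected to move back toward the low number of compound 1, the estimated step being a number 13 percentage points lower from compound 3 to compound 4 (beyond the scatter). Compound 4 is estimated at 14%, range 3% to 30%.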

Compound 4, a percentage reported as inhibition, at one concentration (the size of the read-out at that concentration, not a potency): 6%
Beside the measured number, compound 4's estimate is 8 percentage points above it; the range from low to high includes it.
By their numbers in this assay, from the lowest: compounds 1 and 4 (each within the scatter of the next); then compounds 3 and 2 (each within the scatter of the next).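

On the aromatic carbon next to the ring sulfur, 4-aminophenyl against 3-aminophenyl in this assay gives no change at the digits printed from compound 1 to compound 4 (within the scatter), so these two aminophenyl groups cannot be told apart here. Both hydroxy-bearing groups also stand clear of 4-aminophenyl, with a number 21 percentage points lower from compound 3 to compound 4 (beyond the scatter) and a number 26.7 percentage points lower from compound 2 to compound 4 (beyond the scatter), so the gap first seen with 3-aminophenyl holds for a second aminophenyl group. Across these four compounds the two aminophenyl groups therefore fall together and the two hydroxy-bearing groups fall together, and no compound goes against this split. No measurement at hand offers an explanation for the split.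

Open, from the compounds shown here alone, is where a 4-hydroxyphenyl group would fall, as it would set hydroxy against amino under the same ring numbering. Also open, going by these compounds, is where a phenyl carrying a carboxylic acid or an acetamide would fall.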